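A few compounds are considered here, and "the series" means these few. Any claim that something is new, unique, unknown or untested is made for them only; others in the source may bear on it.

Three compounds share one core and differ only in the aryl group attached to the two-carbon chain next to the ketone. Compound 1 `COc1ccc(C(=O)/C=C/c2ccc(F)cc2)c2c1C=CC(C)(C)O2` carries a 4-fluorophenyl group there. In a functional assay on SK-OV-3 cells (Homo sapiens) for antiproliferative activity, read by MTT assay, with a stated time of 24 h (on this read-out higher numbers stand for weaker inhibition and lower numbers for stronger inhibition), compound 1 gives > 10000 nM, which is a limit of the assay rather than a number. Compound 2 `COc1ccc(C(=O)/C=C/c2ccsc2)c2c1C=CC(C)(C)O2` carries a thiophen-3-yl group instead. In this assay compound 2 gives > 10000 nM, again only a limit. Compound 3 `COc1ccc(C(=O)/C=C/c2ccco2)c2c1C=CC(C)(C)O2` carries a furan-2-yl group. In this assay compound 3 gives > 10000 nM, once more a limit. Compound 3 thus stands exactly where all measured values stand: the limit of > 10000 nM in this assay, at which 3 of the 3 values shown sit. For this reason the steps a step that the two limits leave unreadable from compound 1 to compound 2, a step that the two limits leave unreadable from compound 1 to compound 3 and a step that the two limits leave unreadable from compound 2 to compound 3 have no readable size, and none of them shows whether exchanging one aryl group for another shifts activity at all.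

Compound 4 `COc1ccc(C(=O)/C=C/c2cccs2)c2c1C=CC(C)(C)O2` differs from compound 3 by thiophen-2-yl in place of furan-2-yl on a double-bonded chain carbon bound to a double-bonded chain carbon. For the measured compounds named here, no measured step with a readable size bears on this exchange, so the only guide is that every neighbour of compound 4 sits at the limit. The step that the limit leaves unreadable from compound 3 to compound 4 is therefore expected to stay within the scatter. Compound 4 is expected to give about 12000 nM in this assay, with a plausible range from 3000 nM to 40000 nM, most likely again reported only as a limit.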

Compound 4, half-maximal inhibitory concentration: > 10000 nM
Compound 4 gave a limit, no number; the forecaster's own chance of this, stated with the estimate: 75%; the middle value does not contradict the limit.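

Compound 4 also gives only a limit of the assay, not a number, so no step linking it to compound 1, compound 2 or compound 3 can be read, and all four compounds stand at the same point: the limit of > 10000 nM in this assay, at which 4 of the 4 values shown sit.

The compounds shown leave open whether exchanging one of these aryl groups for another changes activity at all in this assay.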